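A few compounds are considered here, and "the series" means these few. Any claim that something is new, unique, unknown or untested is made for them only; others in the source may bear on it.

Three compounds share one core and differ only in the ring attached to it. Compound 1 `Cc1ccc(-c2nnc(SCCn3c([N+](=O)[O-])cnc3C)o2)cc1` carries a 4-methylphenyl group; in a functional assay on SGC-7901 cells (Homo sapiens) for cytotoxicity, read by MTT assay, with a stated time of 48 h (on this read-out higher numbers stand for weaker inhibition and lower numbers for stronger inhibition), compound 1 gives 12500 nM, the lowest number among the three. Compound 2 `Cc1ncc([N+](=O)[O-])n1CCSc1nnc(-c2ccccc2N)o1` carries a 2-aminophenyl group, and in this assay compound 2 gives 35100 nM. Compound 3 `Cc1ncc([N+](=O)[O-])n1CCSc1nnc(-c2ccc(N)nc2)o1` carries a 6-aminopyridin-3-yl group, and in this assay compound 3 gives 30900 nM. The two swaps away from 4-methylphenyl gave a 2.8-fold higher number from compound 1 to compound 2 (0.45 log units; beyond the scatter) and a 2.5-fold higher number from compound 1 to compound 3 (0.39 log units; beyond the scatter), while a 1.1-fold lower number from compound 2 to compound 3 (0.06 log units; within the scatter). Compound 4 `Cc1ncc([N+](=O)[O-])n1CCSc1nnc(-c2ccnc(Cl)c2)o1` is not yet measured; it differs from compound 1 in one place: 2-chloropyridin-4-yl in place of 4-methylphenyl on an aromatic carbon. The steps from compound 1 to compound 2 and from compound 1 to compound 3 bear on this change. Both replaced the 4-methylphenyl group with a ring carrying an amino group or a ring nitrogen, and both gave modest higher numbers. A step of similar size, toward a higher number, is therefore expected here, as a 1.8-fold higher number from compound 1 to compound 4 (0.25 log units; within the scatter). Compound 4 is estimated at 22000 nM, with a range from 10000 nM to 45000 nM.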

Compound 4, half-maximal inhibitory concentration: 32300 nM
Estimate against measurement, compound 4: 1.5-fold (0.17 log units) below; low and high end bracket the measured number.
By their numbers in this assay, from the lowest: compound 1; then compounds 3, 4 and 2 (each within the scatter of the next).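

The 2-chloropyridin-4-yl group carries no amino group and no hydrogen-bond donor, yet putting it in place of 4-methylphenyl still gives a 2.6-fold higher number from compound 1 to compound 4 (0.41 log units; beyond the scatter) in this assay and shows that an amino group is not required for a step of this size. Compound 4 also cannot be told apart from the two amino-bearing compounds, with a 1.0-fold higher number from compound 3 to compound 4 (0.02 log units; within the scatter) and a 1.1-fold lower number from compound 2 to compound 4 (0.04 log units; within the scatter) as the steps between them, so these three different rings read alike here while 4-methylphenyl stands apart from all of them. Nothing measured here explains why the numbers differ.

The compounds shown leave open whether the lower number of compound 1 depends on its methyl group or on its ring of carbon only. A plain phenyl or a 4-chlorophenyl group at this position would help separate these possibilities.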